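Dimethylamino for cyclohexylmethyl: an expected paw-edema outcome

A few compounds are considered here, and "the series" means these few. Any claim that something is new, unique, unknown or untested is made for them only; others in the source may bear on it.

Compound 1 `C/C(=N\OCC(=O)O)c1ccc(CC2CCCCC2)cc1`: < 20%
Compound 2 `C/C(=N\OCC(=O)O)c1ccc(C#N)cc1`: < 20%
Compound 3 `CSc1ccc(/C(C)=N/OCC(=O)O)cc1`: < 20%

The measurements come from a functional assay on the whole organism for inhibition, with Rattus norvegicus as the target, read by paw edema, with stated times of 1 h and 3 h, at a dose of 50 mg/kg by the oral route; a higher number here means more inhibition at the dose given (going by the name of the read-out), a lower number less inhibition. For compound 1 the value shown is a limit of the assay, not a number. For compound 2 the value is likewise a limit. For compound 3 it is a limit as well. Compound 1 therefore has no readable position within this series; all that can be said is the limit of < 20% in this assay, at which 3 of the 3 values shown sit. The change from compound 1 to compound 4 `C/C(=N\OCC(=O)O)c1ccc(N(C)C)cc1` is dimethylamino in place of cyclohexylmethyl on an aromatic carbon. The measured steps that touch the same aromatic carbon are a step that the two limits leave unreadable from compound 1 to compound 2 and a step that the two limits leave unreadable from compound 1 to compound 3, while a step that the two limits leave unreadable from compound 2 to compound 3 connects the other two; none of them is readable in size, so no direction can be taken from them. In this assay compound 4 is expected at 10%, with a range from 0% to 25%, because of the limit of < 20% in this assay, at which 3 of the 3 values shown sit. The step this estimate means, a step that the limit leaves unreadable from compound 1 to compound 4, is expected to stay within the scatter, most likely ending at the same limit.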

Compound 4, a percentage reported as inhibition, in the whole organism at one dose (the size of the read-out at that dose, not a potency): < 20%
Compound 4: a limit, no number; the forecaster's own chance of this, stated with the estimate: 80%; the middle value is on the limit's open side.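

In this assay, compound 4 joins compound 1, compound 2 and compound 3 in giving a limit rather than a number, and no step among these four can be read. The compounds shown leave open whether any group on this aromatic carbon gives a readable inhibition at the dose given.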